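Trimming a Methyl from the Amine of Compound 2

The compounds below may be only part of what the source reports. "The series", "measured", "known", "first", "only" and "open" are said of these compounds alone.

Of the compounds shown here, two sharing one core have been tested in a functional assay on the whole organism with Mus musculus as the target; a lower number here means that less compound is needed, a higher number that more compound is needed for the effect. Compound 1 `CC(N)c1nnc(-c2ccccc2-c2ccccc2)s1` carries a 1-aminoethyl group on the core, and in this assay compound 1 gives 32 mg/kg. Compound 2 `CN(C)Cc1nnc(-c2ccccc2-c2ccccc2)s1` carries a (dimethylamino)methyl group instead, and in this assay compound 2 gives 35 mg/kg. Among the compounds with values here, the one step that links them, a 1.1-fold higher number from compound 1 to compound 2 (0.04 log units; within the scatter), lies within the scatter. On the two numbers shown, compound 2 therefore sits alongside compound 1, and no order between them can be read.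

Compound 3 `CNCc1nnc(-c2ccccc2-c2ccccc2)s1` has not yet been measured. It differs from compound 2 by hydrogen in place of methyl on an amine nitrogen. Within the data shown here, no measured step removes a single methyl from the amine nitrogen. Among the measured compounds shown here, the only step available, a 1.1-fold higher number from compound 1 to compound 2 (0.04 log units; within the scatter), reshaped the whole amine group and still stayed within the scatter. On that basis, no step beyond the scatter is expected for compound 3 in this assay. Compound 3 is expected to give about 33 mg/kg, within a range from 17 mg/kg to 66 mg/kg. The expected step is a 1.1-fold lower number from compound 2 to compound 3 (0.03 log units; within the scatter).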

Compound 3, dose for half-maximal effect: 20 mg/kg
The estimate for compound 3 lay 1.7-fold (0.22 log units) above the measured number, within the range that was stated.
By their numbers in this assay, from the lowest: compounds 3, 1 and 2 (each within the scatter of the next).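

In this assay, the amine nitrogen now has a measured change at a single place: hydrogen in place of methyl gives the step (a 1.8-fold lower number from compound 2 to compound 3 (0.24 log units; within the scatter)), so losing this methyl produces no step beyond the scatter. The comparison with the branched primary amine points the same way (a 1.6-fold lower number from compound 1 to compound 3 (0.20 log units; within the scatter)), and the (methylamino)methyl group cannot be told apart from the 1-aminoethyl group on this aromatic carbon. All three amine-bearing groups shown therefore give numbers that cannot be ordered, and no measurement at hand speaks to what lies behind them.

All of the compounds shown keep a nitrogen in this side chain, so it remains open whether the number would hold with a group lacking that nitrogen, such as hydroxymethyl or a plain ethyl chain. Also open, from the compounds shown here alone, is how far the amine can be varied before a step beyond the scatter appears, for example with the unsubstituted aminomethyl group or with the larger diethylamino group in place of dimethylamino.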